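The source may report more compounds than this note shows. Statements on the series, on what has been measured and on what is new or still open speak of the compounds shown alone.

Two compounds of the shared core carry a substituted phenyl on the triple-bonded carbon. Compound 1 `CNC(=O)[C@@]12C[C@@H]1[C@@H](n1cnc3c(NC)nc(C#Cc4ccccc4F)nc31)[C@H](O)[C@@H]2O` gives 20% in an assay on CHO cells for displacement of a labelled ligand from adenosine receptor A1 (Homo sapiens), read by scintillation counting, with a stated time of 60 min, tested at 10 uM; a lower number here means less inhibition, a higher number more inhibition at the concentration tested (going by the name of the read-out). Compound 2 `CNC(=O)[C@@]12C[C@@H]1[C@@H](n1cnc3c(NC)nc(C#Cc4ccc(Cl)cc4)nc31)[C@H](O)[C@@H]2O` gives 13% in this assay. Compound 2 holds the smaller of the two numbers, yet the step of a number 7 percentage points lower from compound 1 to compound 2 (within the scatter) is within the scatter, so the two compounds cannot be told apart on these data.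

Compound 3 `CNC(=O)[C@@]12C[C@@H]1[C@@H](n1cnc3c(NC)nc(C#Cc4ccc(OC)cc4)nc31)[C@H](O)[C@@H]2O` has not been measured in this assay. Against compound 2 it carries methoxy in place of chloro on an aromatic carbon. Among the compounds with values here, the only measured step that bears on it, a number 7 percentage points lower from compound 1 to compound 2 (within the scatter), exchanged one substituted phenyl for another at the same triple-bonded carbon and stayed within the scatter; no measured step involves a methoxy. A change of the same kind on the same ring is therefore expected to give no step beyond the scatter in this assay, an expected a number 2 percentage points higher from compound 2 to compound 3 (within the scatter). For compound 3 the estimate in this assay is 15%, with an expected range from 0% to 35%.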

Compound 3, a percentage reported as inhibition, at one concentration (the size of the read-out at that concentration, not a potency): 10%
Estimate against measurement, compound 3: 5 percentage points above; low and high end bracket the measured number.
By their numbers in this assay, from the lowest: compounds 3, 2 and 1 (each within the scatter of the next).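

Methoxy in place of chloro on the same aromatic carbon gives a number 3 percentage points lower from compound 2 to compound 3 (within the scatter) in this assay and is the first change shown at this ring position with the ring pattern held fixed: a chlorine leaves, a hydrogen-bond acceptor enters, and the step stays inside the scatter. Across substitution sites, 4-methoxyphenyl in place of 2-fluorophenyl gives a number 10 percentage points lower from compound 1 to compound 3 (within the scatter) in this assay and also stays inside it, so the three substituted phenyls on the triple-bonded carbon cannot be told apart in this assay. Nothing available explains these numbers.

Open, going by these compounds, is whether an amine, a carboxylic acid or a longer chain on this phenyl ring would give a step beyond the scatter. Also open, on these data alone, is what a pyridine in place of the phenyl ring would do on the triple-bonded carbon.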